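Swapping an Aryl Amide for a Urea

The source may report more compounds than this note shows. Statements on the series, on what has been measured and on what is new or still open speak of the compounds shown alone.

Compound 1 `CC(C)(C)c1cc(NC(=O)[C@@H]2CCCCN2C2CCOCC2)no1`, compound 2 `CC(C)(C)c1cc(NC(=O)[C@@H]2CCCCN2C(=O)c2ccccc2)no1` and compound 3 `CC(C)(C)c1cc(NC(=O)[C@@H]2CCCCN2C(=O)c2ccc(Cl)cc2)no1` share one core and differ only at the group carried by the ring nitrogen. In a physicochemical assay for solubility, read by HPLC, at pH 6.8 (a lower number here means a less soluble compound, a higher number a more soluble compound), compound 1 gives 74 ug/mL and compound 2 gives 0.9 ug/mL. For compound 3 this assay reports only a limit, < 0.1 ug/mL, which is the limit of < 0.1 ug/mL in this assay, at which 1 of the 3 values shown sits. The measured steps were all downward: an 82-fold lower number from compound 1 to compound 2 (1.91 log units; beyond the scatter), then an at least 9.0-fold lower number from compound 2 to compound 3 (0.95 log units; beyond the scatter), and in one stride an at least 740-fold lower number from compound 1 to compound 3 (2.86 log units; beyond the scatter). Compound 3 therefore sits at the bottom of the three.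

Compound 4 `CC(C)(C)c1cc(NC(=O)[C@@H]2CCCCN2C(=O)N2CCCCC2)no1` is the next step: piperidin-1-yl in place of 4-chlorophenyl on a carbonyl carbon, so the (4-chlorophenyl)carbonyl of compound 3 becomes a (piperidin-1-yl)carbonyl, a urea. The step from compound 2 to compound 3 bears directly, since the chloro leaves again, and the step from compound 1 to compound 2 bears loosely, since an aromatic ring is exchanged for a saturated one. An upward step in this assay is expected, an at least 50-fold higher number from compound 3 to compound 4 (1.69 log units; beyond the scatter), and compound 4 is estimated at 5 ug/mL, within 0.5 ug/mL to 40 ug/mL.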

Compound 4, solubility: 49 ug/mL
The estimate for compound 4 lay 9.8-fold (0.99 log units) below the measured number; the whole stated range lies below it.
By their numbers in this assay, from the lowest: compound 2; then compounds 4 and 1 (each within the scatter of the next). At a limit, below all of these: compound 3.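

Putting piperidin-1-yl on the carbonyl carbon in place of an aromatic ring gives, in this assay, an at least 490-fold higher number from compound 3 to compound 4 (2.69 log units; beyond the scatter) and a 54-fold higher number from compound 2 to compound 4 (1.74 log units; beyond the scatter), so a carbonyl on the ring nitrogen does not by itself bring the low numbers of the two aryl amides. The urea also matches the amine carrying oxan-4-yl, with a 1.5-fold lower number from compound 1 to compound 4 (0.18 log units; within the scatter), so this position can hold a carbonyl without the number falling away. The step up from compound 3 has a limit, not a number, at its lower end: the limit of < 0.1 ug/mL in this assay, at which 1 of the 4 values shown sits.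

As far as these compounds go, whether a morpholin-4-yl or dimethylamino group on the same carbonyl carbon would read like compound 4 remains open. So does the behaviour of a cyclohexyl group there, which would separate losing the aromatic ring from gaining the urea nitrogen.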